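The source may report more compounds than this note shows. Statements on the series, on what has been measured and on what is new or still open speak of the compounds shown alone.

Measured so far:
Compound 1, `Cc1ccc(C2=NN(c3nc(-c4ccc(F)cc4)cs3)C(c3ccc(F)cc3)C2)s1`, gives > 500 ug/mL.
Compound 2, `Fc1ccc(C2CC(c3ccc(Cl)s3)=NN2c2nc(-c3ccc(C(F)(F)F)cc3)cs2)cc1`, gives > 500 ug/mL.
Compound 3, `Fc1ccc(-c2csc(N3N=C(c4ccc(Cl)s4)CC3c3ccc(F)cc3)n2)cc1`, gives > 500 ug/mL.

These three compounds share one core and were all tested in an ADME assay on NIH3T3 cells (Mus musculus) for cytotoxicity, read by XTT assay, with a stated time of 24 h; a lower number here means a stronger inhibitor, a higher number a weaker inhibitor. The value of compound 1 is a limit of the assay, not a number. The value of compound 2 is likewise only a limit. Compound 3 also stands at a limit. Because all three values sit at the limit of > 500 ug/mL in this assay, at which 3 of the 3 values shown sit, the step that the two limits leave unreadable from compound 1 to compound 3 cannot be read, and neither can a step that the two limits leave unreadable from compound 2 to compound 3.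

Compound 4, `Cc1ccc(C2=NN(c3nc(-c4ccc(Cl)cc4)cs3)C(c3ccc(F)cc3)C2)s1`, has not yet been measured. It differs from compound 1 by chloro in place of fluoro on an aromatic carbon. Going by the values given here, no measured step bears on this exact change, and the two steps that are known are both unreadable because every value rests at the limit of > 500 ug/mL in this assay, at which 3 of the 3 values shown sit. Among the compounds with values here, there is thus nothing among the measured compounds pointing to compound 4 leaving the region where the others lie. Compound 4 is therefore expected to show a step that the limit leaves unreadable from compound 1 to compound 4 in this assay. For compound 4 the estimated value is 700 ug/mL, with an expected range from 300 ug/mL to 2000 ug/mL, and most probably the assay will again report only a limit.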

Compound 4, half-maximal inhibitory concentration: > 500 ug/mL
Compound 4: no number, only a limit; the forecaster's own chance of this, stated with the estimate: 85%; the middle value is on the limit's open side.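

No size can be read for the step from compound 1 to compound 4, chloro in place of fluoro, because each of the two values is a limit of this assay and not a number: the limit of > 500 ug/mL in this assay, at which 4 of the 4 values shown sit.

The compounds shown leave open whether any of these changes on the shared core shifts the value in this assay at all, and by how much.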